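Working notes: cytotoxicity of compounds 1 to 4

The compounds below may be only part of what the source reports. "The series", "measured", "known", "first", "only" and "open" are said of these compounds alone.

Compound 3 `Cc1cc(C)cc(S(=O)(=O)c2c(C(=O)NCC(=O)NCc3ccncc3)[nH]c3ccc(Cl)cc23)c1` stands at a limit rather than a number in an ADME assay on MT4 cells (Homo sapiens) for cytotoxicity, read by MTT assay (on this read-out lower numbers stand for higher toxicity in this test and higher numbers for lower toxicity in this test), where compound 3 gives > 48900 nM. Compound 1 `Cc1cc(C)cc(S(=O)(=O)c2c(C(=O)NC(c3ccc(Cl)cc3)C3CC3)[nH]c3ccc(Cl)cc23)c1` also sits at a limit of this assay, giving > 47300 nM. Compound 2 `Cc1cc(C)cc(S(=O)(=O)c2c(C(=O)NCC(=O)NCc3ccco3)[nH]c3ccc(Cl)cc23)c1` likewise gives only a limit, > 50000 nM. Among the measured compounds shown here, all three values shown are therefore limits, as the limit of > 47300 nM in this assay, at which 1 of the 3 values shown sits, the limit of > 48900 nM in this assay, at which 1 of the 3 values shown sits, and the limit of > 50000 nM in this assay, at which 1 of the 3 values shown sits, record, and none of the measured steps can be sized: a step that the two limits leave unreadable from compound 1 to compound 2, a step that the two limits leave unreadable from compound 1 to compound 3 and a step that the two limits leave unreadable from compound 2 to compound 3 are all unreadable between their limits.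

Compound 4 `Cc1cc(C)cc(S(=O)(=O)c2c(C(=O)NCc3cccc(F)c3F)[nH]c3ccc(Cl)cc23)c1` differs from compound 3 by 2,3-difluorophenyl in place of ((pyridin-4-yl)methyl)carbamoyl on a saturated chain carbon bound to an amide-type nitrogen; cut one bond further out the change reads (((pyridin-4-yl)methyl)carbamoyl)methyl to 2,3-difluorobenzyl. The steps bearing on this change, all on the same amide-type nitrogen side of the shared core, are the three unreadable ones above, so no readable step in this assay is expected in either direction. Compound 4 is therefore expected to give 50000 nM, with a range from 20000 nM to 120000 nM. The step that the limit leaves unreadable from compound 3 to compound 4 is expected to remain unreadable against the limit.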

Compound 4, half-maximal cytotoxic concentration: > 51100 nM
Compound 4: only a limit was reported; the forecaster's own chance of this, stated with the estimate: 85%; middle value at least 1.0-fold (0.00 log units) away from the limit.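

Compound 4 gives only a limit in this assay, > 51100 nM, so its steps to compound 1, compound 2 and compound 3 cannot be read. The compounds shown leave open at what concentration any of the four turns cytotoxic, and whether their different groups on the amide-type nitrogen change that concentration at all.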